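Amide-nitrogen swap at compound 2: carboxy group enters

The source may report more compounds than this note shows. Statements on the series, on what has been measured and on what is new or still open speak of the compounds shown alone.

Values in a functional assay on BXPC-3 cells (Homo sapiens) for antiproliferative activity, read by MTT assay, with a stated time of 24 h; on this read-out higher numbers stand for weaker inhibition and lower numbers for stronger inhibition:
- compound 1 `CCn1c(C(=O)NC(C)(C)CO)ccc1C(CC)(CC)c1ccc(OCS(=O)(=O)c2ccccc2)c(C)c1` gives 18300 nM
- compound 2 `CCn1c(C(=O)N[C@@H](CO)CCCO)ccc1C(CC)(CC)c1ccc(OCS(=O)(=O)c2ccccc2)c(C)c1` gives 16400 nM

Compound 2 stands within the scatter of compound 1, so the two numbers shown do not separate them. The next structure is compound 3 `CCn1c(C(=O)N[C@@H](C(=O)O)C(C)C)ccc1C(CC)(CC)c1ccc(OCS(=O)(=O)c2ccccc2)c(C)c1`, and the change is a group of 7 heavy atoms (5 carbon, 2 oxygen; no ring) in place of a group of 7 heavy atoms (5 carbon, 2 oxygen; no ring), on an amide-type nitrogen. Here 1-carboxy-2-methylpropyl enters on an amide-type nitrogen whose other neighbour is the carbonyl carbon.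

Among the compounds with values here, only one measured step bears on this: a 1.1-fold lower number from compound 1 to compound 2 (0.05 log units; within the scatter). Within the data shown here, it is a change at the same amide-type nitrogen, but no measured compound carries the entering group, so its support is thin. On that basis, no step beyond the scatter is expected in this assay, and no direction can be favoured with any confidence. The range is kept wide for this reason.

The expected step is a 1.2-fold higher number from compound 2 to compound 3 (0.09 log units; within the scatter).

The estimate for compound 3 is 20000 nM, with an expected range of 7000 nM to 50000 nM.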

Compound 3, half-maximal inhibitory concentration: 13900 nM
Compound 3: middle estimate off by 1.4-fold (0.16 log units), on the high side, and the stated range covers the measured number.
By their numbers in this assay, from the lowest: compounds 3, 2 and 1 (each within the scatter of the next).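

Placing 1-carboxy-2-methylpropyl on the amide-type nitrogen gives the first carboxy-bearing group at this position in this assay, and the comparison with the hydroxyl-bearing group of compound 2 reads as a 1.2-fold lower number from compound 2 to compound 3 (0.07 log units; within the scatter). The comparison with 1-(hydroxymethyl)-1-methylethyl reads as a 1.3-fold lower number from compound 1 to compound 3 (0.12 log units; within the scatter), so all three groups now shown at this nitrogen remain unseparated on this read-out, and exchanging the hydroxyl-bearing groups for this carboxy-bearing group brings no step beyond the scatter. No measured information is available to account for this result.

Whether any group at this nitrogen can produce a step beyond the scatter remains open, since an amine, a phenyl ring or a longer chain ending in a carboxylic acid would each test this position in a way that the three compounds shown cannot. Also open, going by these compounds, are the effect of the opposite configuration at the defined stereocentre of 1-carboxy-2-methylpropyl and whether changes elsewhere on the shared core would behave differently with this group in place.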